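A few compounds are considered here, and "the series" means these few. Any claim that something is new, unique, unknown or untested is made for them only; others in the source may bear on it.

Compound 1, `Cc1c(C(=O)NCc2cccc(C(F)(F)F)c2)cnn1-c1ccc(Cl)c(Cl)c1`, in a functional assay on cells for antagonist activity at C-C chemokine receptor type 1 (Homo sapiens), read by FLIPR and calcium flux (a higher number here means a weaker inhibitor, a lower number a stronger inhibitor), gives 500 nM.
Compound 2, `Cc1c(C(=O)NCc2cccc(C(F)(F)F)c2)cnn1-c1cccc(C(F)(F)F)c1`, in this assay gives > 3000 nM, which is a limit of the assay and not a number.

Compound 2 therefore stands at the edge of what this assay can report, at the limit of > 3000 nM in this assay, at which 1 of the 2 values shown sits. Compound 3, `Cc1c(C(=O)NCc2cccc(C(F)(F)F)c2)cnn1Cc1ccccc1`, differs from compound 2 in one place: benzyl in place of 3-(trifluoromethyl)phenyl on an aromatic nitrogen. Among the compounds with values here, the only measured step, an at least 6.0-fold higher number from compound 1 to compound 2 (0.77 log units; beyond the scatter), swaps the group on the same aromatic nitrogen and already pushed the number to the limit; it shows that this position is sensitive, but no measured step covers a benzyl there. With compound 2 already at the limit, a weak result is expected for compound 3 as well, and the estimated step that the limit leaves unreadable from compound 2 to compound 3 is uncertain in direction. Compound 3 is expected to give 5000 nM in this assay, between 1500 nM and 20000 nM, with a good chance that only a limit is reported.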

Compound 3, half-maximal inhibitory concentration: > 3000 nM
Compound 3: a limit, no number; the forecaster's own chance of this, stated with the estimate: 65%; the middle value is on the limit's open side.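

Putting benzyl in place of 3,4-dichlorophenyl on the aromatic nitrogen gives an at least 6.0-fold higher number from compound 1 to compound 3 (0.77 log units; beyond the scatter) in this assay, so a second, quite different group at this position also compares poorly with compound 1. The step between compound 2 and compound 3 cannot be read, so these two replacements cannot be ranked against each other. Compound 2 and compound 3 sit at the same limit of the assay, which is not a number: the limit of > 3000 nM in this assay, at which 2 of the 3 values shown sit.

From the compounds shown here alone, how far either compound lies past that limit remains unknown. Also open, going by these compounds, is whether a 3,4-dichlorobenzyl group, a longer chain such as phenethyl, or a benzyl carrying an amine on this nitrogen would give a measurable value and show what compound 1 has that these two lack.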